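Working notes: the step from compound 3 to compound 4

The source may hold more compounds than are shown below. What is called first, only, known or untested is meant among the compounds shown, and "the series" means these compounds.

- compound 1 `COc1ccc(N(C)c2nc(C)nc3ccccc23)cc1OCCCCCC[Se]C#N` (5520 nM)
- compound 2 `COc1ccc(N(C)c2nc(C)nc3ccccc23)cc1C(=O)OCCC[Se]C#N` (250 nM)
- compound 3 `COc1ccc(N(C)c2nc(C)nc3ccccc23)cc1OCCCC[Se]C#N` (1200 nM)

In a functional assay on A549 cells (Homo sapiens) for inhibition, read by MTT assay, with a stated time of 48 h (on this read-out lower numbers stand for stronger inhibition and higher numbers for weaker inhibition), compound 3 (1200 nM) stands in the middle of the three, with compound 1 (5520 nM) higher and compound 2 (250 nM) lower. The change to compound 4 `COc1ccc(N(C)c2nc(C)nc3ccccc23)cc1[Se]C#N` is a group of 3 heavy atoms (1 carbon, 1 nitrogen, 1 selenium; no ring) in place of a group of 8 heavy atoms (5 carbon, 1 nitrogen, 1 oxygen, 1 selenium; no ring), on an aromatic carbon and the site is ortho to a methoxy group. Among the measured compounds shown here, the closest precedent is a 4.6-fold lower number from compound 1 to compound 3 (0.66 log units; beyond the scatter) and there a smaller group goes with a lower number. The large step of a 22-fold lower number from compound 1 to compound 2 (1.34 log units; beyond the scatter) also runs toward a smaller group. Compound 2 goes against this pattern in a 4.8-fold higher number from compound 2 to compound 3 (0.68 log units; beyond the scatter) with the smaller group on the higher side. Group size alone therefore gives only a loose guide. In this assay a modest step toward a lower number is expected, with the direction not secure. The expected step is a 2.4-fold lower number from compound 3 to compound 4 (0.38 log units; beyond the scatter) on this estimate. The value estimated for compound 4 is 500 nM (expected range 100 nM to 2500 nM).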

Compound 4, half-maximal inhibitory concentration: 49 nM
Beside the measured number, compound 4's estimate is 10-fold (1.01 log units) above it; measured number below the stated range.
By their numbers in this assay, from the lowest: compound 4; then compound 2; then compound 3; then compound 1.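

In this assay, among the compounds shown here, the chain linker is gone in compound 4, leaving the selenium-bound nitrile directly on the aromatic carbon ortho to a methoxy group, and this gives a 24-fold lower number from compound 3 to compound 4 (1.39 log units; beyond the scatter); the earlier compounds, all of which keep a linker, did not show that this site accepts the group without one. The unlinked group also outdoes the carbonyl-containing linker, with a 5.1-fold lower number from compound 2 to compound 4 (0.71 log units; beyond the scatter), and the longest chain shown, with a 110-fold lower number from compound 1 to compound 4 (2.05 log units; beyond the scatter), so the number falls as the group shrinks across the series, although compound 2 goes against this order relative to compound 3. No measurement available here accounts for the drop.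

As far as these compounds go, how a plain nitrile, a thiocyanate or an amine on this same aromatic carbon would compare remains open. Also open, from the compounds shown here alone, is whether this order of the four compounds carries over to other cell lines.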